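The source may report more compounds than this note shows. Statements on the series, on what has been measured and on what is new or still open speak of the compounds shown alone.

Working notes on the series.

Two cores are in hand. Compound 1 `Cc1cnc(N)nc1-c1ccccc1` and compound 2 `Cc1cncnc1-c1ccccc1` are built on one of them; compound 3 `CN1CCc2nc(N)ncc2C1` and compound 4 `CN1CCc2ncncc2C1` on the other. How the two cores differ is not broken down here.

In a functional assay on the whole organism for inhibition, with Rattus norvegicus as the target, with stated times of 1 h and 3.5 h, at a dose of 100 mg/kg by the oral route (on this read-out lower numbers stand for less inhibition and higher numbers for more inhibition at the one dose given (going by the name of the read-out)), compound 1 gives 34%. In this assay compound 2 gives 48%. For the measured compounds named here, the one change between them is hydrogen in place of amino on an aromatic carbon, and it produced a number 14 percentage points higher from compound 1 to compound 2 (beyond the scatter).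

Compound 3 is reported only as a limit in this assay, namely < 5%, which is the limit of < 5% in this assay, at which 1 of the 3 values shown sits.

Compound 4 has not been measured in this assay. Going by the values given here, it is related to compound 3 by the same kind of change as the one from compound 1 to compound 2: hydrogen in place of amino on an aromatic carbon. What differs around the place is that in compound 3 the ring is part of a fused or bridged system of two rings, meta to a fused ring and para to a fused ring, whereas in compound 1 the place is meta to a group of 6 heavy atoms and para to a methyl group.

The expectation for the step from compound 3 to compound 4 rests on compound 1 and compound 2, where the same kind of change gave a number 14 percentage points higher from compound 1 to compound 2 (beyond the scatter); a step of about that size, a number at least 7 percentage points higher from compound 3 to compound 4 (that floor lies within the scatter), is expected here as well, with the caveat that the starting value of compound 3 is a limit. Compound 4 is accordingly estimated at 12% in this assay, with a range from 3% to 28%, and a fair chance that only a limit is reported again.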

Compound 4, a percentage reported as inhibition, in the whole organism at one dose (the size of the read-out at that dose, not a potency): 50%
For compound 4 the middle estimate is 38 percentage points below the measured one, outside the stated range (above it).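

In this assay, hydrogen in place of amino on an aromatic carbon gives a higher number on both cores, a number 14 percentage points higher from compound 1 to compound 2 (beyond the scatter) and a number at least 45 percentage points higher from compound 3 to compound 4 (beyond the scatter), so the direction of the change carries from one core to the other while its size does not: the same change on two cores in this assay, a number 14 percentage points higher (beyond the scatter) from compound 1 to compound 2 and a number at least 45 percentage points higher (beyond the scatter) from compound 3 to compound 4, at least 31 percentage points apart, beyond the scatter of two such steps

The value of compound 3, < 5%, is a limit and not a number, so the step on that core has a floor but no known size: the limit of < 5% in this assay, at which 1 of the 4 values shown sits.

Two cores are too few to show that the direction would hold on a third core, and these results do not show why the size of the step depends on the core, nor how much of it would remain at another dose, since the read-out gives the size of the effect at one dose and not a potency.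

The compounds shown leave open how other groups at this place between two ring nitrogen atoms would compare with amino and hydrogen on either core, for example a methylamino group, a dimethylamino group or a methyl group. They also leave open whether such groups would give steps that differ between the two cores, as the change from amino to hydrogen does.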